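Chain extension at the alkyne terminus

The source may report more compounds than this note shows. Statements on the series, on what has been measured and on what is new or still open speak of the compounds shown alone.

Within the data shown here, compound 2 `CC#CCN(CC[C@H](N)C(=O)O)C[C@H]1O[C@@H](n2cnc3c(N)ncnc32)[C@H](O)[C@@H]1O` gives 39700 nM in an assay for inhibition of tRNA (cytosine(38)-C(5))-methyltransferase (Homo sapiens), read by isothermal titration calorimetry; a higher number here means a weaker inhibitor, a lower number a stronger inhibitor; its only measured neighbour is compound 1 `C#CCN(CC[C@H](N)C(=O)O)C[C@H]1O[C@@H](n2cnc3c(N)ncnc32)[C@H](O)[C@@H]1O`, which gives 77100 nM, and the step of a 1.9-fold lower number from compound 1 to compound 2 (0.29 log units; within the scatter) lies within the scatter. Compound 3 `CCC#CCN(CC[C@H](N)C(=O)O)C[C@H]1O[C@@H](n2cnc3c(N)ncnc32)[C@H](O)[C@@H]1O` carries methyl in place of hydrogen on a saturated chain carbon bound to a triple-bonded carbon, the same homologation read one bond further out. Among the measured compounds shown here, only the step from compound 1 to compound 2 bears on it, and that step was small, so for compound 3 nothing beyond the scatter is expected in this assay, the expected step being a 1.3-fold lower number from compound 2 to compound 3 (0.12 log units; within the scatter). Compound 3 is estimated at 30000 nM, with a range from 12000 nM to 75000 nM.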

Compound 3, half-maximal inhibitory concentration: 32200 nM
Compound 3: the middle estimate sits 1.1-fold (0.03 log units) below what was measured; low and high end bracket the measured number.
By their numbers in this assay, from the lowest: compounds 3, 2 and 1 (each within the scatter of the next, the first and the last beyond it).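

In this assay this further methyl alone gives a 1.2-fold lower number from compound 2 to compound 3 (0.09 log units; within the scatter) and so adds nothing readable, yet the full change to ethyl on the triple-bonded carbon gives a 2.4-fold lower number from compound 1 to compound 3 (0.38 log units; beyond the scatter) and separates the two ends of the series. Compound 1, compound 2 and compound 3 therefore differ beyond the scatter only at their extremes, with neighbouring compounds staying within it. No accompanying measurement bears on this result.

From the compounds shown here alone, whether a longer chain at the alkyne terminus extends this modest gain remains open, as does the response to an amine or a carboxylic acid at the chain end.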